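Diethylamino for dimethylamino on the basic side chain

The source may hold more compounds than are shown below. What is called first, only, known or untested is meant among the compounds shown, and "the series" means these compounds.

Compound 1 `CN(C)CCCn1c(N)c(-c2nc3ccccc3[nH]2)c2nc(C#N)c(C#N)nc21` and compound 2 `CCN(CC)CCCn1c(N)c(-c2nc3ccccc3[nH]2)c2nc(C#N)c(C#N)nc21` share one core; compound 3 `CN(C)CCCCn1c(N)c(-c2nc3ccccc3o2)c2nc(C#N)c(C#N)nc21` and compound 4 `CCN(CC)CCCCn1c(N)c(-c2nc3ccccc3o2)c2nc(C#N)c(C#N)nc21` share another, and the difference between the two cores is not broken down here. In a functional assay on HL-60 cells (Homo sapiens) for antiproliferative activity, read by MTT assay, with a stated time of 48 h (on this read-out lower numbers stand for stronger inhibition and higher numbers for weaker inhibition), compound 1 gives 870 nM. For compound 2 this assay reports only a limit, > 730 nM. The change from compound 1 to compound 2 is diethylamino in place of dimethylamino on a saturated chain carbon, three bonds along the chain from an aromatic nitrogen; the step that the limit leaves unreadable from compound 1 to compound 2 cannot be read as a number because of the limit of > 730 nM in this assay, at which 1 of the 3 values shown sits. In this assay compound 3 gives 640 nM, a value that sits within the scatter of the number for compound 1. Compound 4 carries the same kind of change as compound 2, (diethylamino in place of dimethylamino on a saturated chain carbon, four bonds along the chain from an aromatic nitrogen); the place differs in that here the amine sits on a saturated chain carbon four bonds along the chain from an aromatic nitrogen, where in compound 2 it sits three bonds along. For the measured compounds named here, from compound 1 and compound 2 the only reading is that the diethylamino compound did not come out with a lower number than its dimethylamino partner. The step of a 1.5-fold higher number from compound 3 to compound 4 (0.17 log units; within the scatter) is therefore expected to be small or to point toward a higher number. A return of only a limit for compound 4 in this assay is a real possibility. Compound 4 is estimated at 950 nM, with an expected range from 400 nM to 2500 nM.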

Compound 4, half-maximal inhibitory concentration: 450 nM
Estimate against measurement, compound 4: 2.1-fold (0.32 log units) above; the range from low to high includes it.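

In this assay, diethylamino in place of dimethylamino on a saturated chain carbon, four bonds along the chain from an aromatic nitrogen, gives a 1.4-fold lower number from compound 3 to compound 4 (0.15 log units; within the scatter), so on this core the two amines cannot be told apart. The matching step on the other core, where the amine sits three bonds along, cannot be read as a number, as compound 2 carries only a limit: the limit of > 730 nM in this assay, at which 1 of the 4 values shown sits. This leaves one readable step in the series, which shows that the change is tolerated on one core without a difference beyond the scatter, but it does not show that the step carries over from one core to the other, and it gives no size for such a transfer.

The compounds shown leave open how much of any difference between the two pairs belongs to the core and how much to the place of the amine on the chain, since the two pairs differ in both. Also open, as far as these compounds go, is whether a primary amine, a carboxylic acid or a longer chain in place of the 3-(dimethylamino)propyl end would move the number beyond the scatter in this assay.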